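A few compounds are considered here, and "the series" means these few. Any claim that something is new, unique, unknown or untested is made for them only; others in the source may bear on it.

Working notes on the hydrazone series.

The set rests on a shared core carried by compound 1 `Cc1nnc(SCC(=O)N/N=c2/scc(-c3ccc(Cl)cc3)n2-c2ccccc2)s1`, compound 2 `Cc1nnc(SCC(=O)N/N=c2/scc(-c3ccc(C#N)cc3)n2-c2ccccc2)s1` and compound 3 `Cc1ccc(-c2cs/c(=N/NC(=O)CSc3ncccn3)n2-c2ccccc2)cc1`, each differing in the aryl group on the core and in the heteroaryl ring attached to the sulfur of the side chain. In a functional assay on C6 cells (Rattus norvegicus) for cytotoxicity, read by MTT assay, with a stated time of 24 h (on this read-out higher numbers stand for weaker inhibition and lower numbers for stronger inhibition), compound 1 gives 28 ug/mL. In this assay compound 2 is recorded as "not determined" (no result reported), so no number is available for it. In this assay compound 3 gives 85 ug/mL, which is the highest of the two numbers on hand; the nearest is compound 1, and the gap between the two lies beyond the usual scatter.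

Compound 4 `Cc1ccc(-c2cs/c(=N/NC(=O)CSc3nnc(C)s3)n2-c2ccccc2)cc1` is not yet measured. It keeps the aryl group of compound 3 and changes only the heteroaryl ring: 5-methyl-1,3,4-thiadiazol-2-yl in place of pyrimidin-2-yl on a sulfur. Among the compounds with values here, no measured pair in the set isolates this change on its own, so its size is not known directly; compound 1 carries the same 5-methyl-1,3,4-thiadiazol-2-yl ring but a different aryl group, which confounds the comparison. On that basis a 1.7-fold lower number from compound 3 to compound 4 (0.23 log units; within the scatter) is expected to be a modest step toward a lower number, possibly no larger than the scatter. Compound 4 is therefore expected at 50 ug/mL, with a range from 20 ug/mL to 120 ug/mL.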

Compound 4, half-maximal inhibitory concentration: 25.3 ug/mL
Compound 4: middle estimate off by 2.0-fold (0.30 log units), on the high side; the range from low to high includes it.
By their numbers in this assay, from the lowest: compounds 4 and 1 (each within the scatter of the next); then compound 3.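

In this assay, within the data shown here, the swap on a sulfur from pyrimidin-2-yl to 5-methyl-1,3,4-thiadiazol-2-yl, with the aryl group held fixed, gives a 3.4-fold lower number from compound 3 to compound 4 (0.53 log units; beyond the scatter) and so provides the first isolated reading of this change, one that lies beyond the scatter. Methyl in place of chloro on an aromatic carbon, with the 5-methyl-1,3,4-thiadiazol-2-yl ring held fixed, gives a 1.1-fold lower number from compound 1 to compound 4 (0.04 log units; within the scatter) and lies within the scatter, so this pair does not separate the two aryl substituents on this read-out. The data at hand offer nothing that would account for either step.

The series shows the heteroaryl swap on the methyl-bearing aryl group only, so whether the step carries over to the chloro-bearing aryl group stays open, since the pyrimidin-2-yl partner of compound 1 is not among the compounds shown. Also open is how an amine or a longer alkyl chain in place of the methyl on the 5-methyl-1,3,4-thiadiazol-2-yl ring would read, as every thiadiazole shown carries that same methyl.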